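Removing one methoxy group from the aminophenyl chalcone-pyrazole

This account rests on a few compounds, and the source may have more. Where it says the series, first, only, none or still open, it means among the compounds named here.

Measured compounds:
compound 1 `COc1ccc(-c2cc(/C=C/C(=O)c3ccc(N)cc3)[nH]n2)cc1` — 58%
compound 2 `COc1cc(-c2cc(/C=C/C(=O)c3ccc(N)cc3)[nH]n2)cc(OC)c1OC` — 43%
compound 3 `COc1cc(-c2cc(/C=C/C(=O)c3ccc(Cl)c(Cl)c3)[nH]n2)cc(OC)c1OC` — 101%

In a functional assay on K562 cells (Homo sapiens) for cytotoxicity, read by sulforhodamine B assay, with a stated time of 48 h, tested at 1 uM (on this read-out lower numbers stand for a stronger effect and higher numbers for a weaker effect at the one concentration tested), compound 2 gives 43%, the lowest number of the three. Compound 1 gives 58% in this assay, and compound 3 gives 101%. Among the compounds with values here, the only single-site step among them is the large one a number 58 percentage points higher from compound 2 to compound 3 (beyond the scatter), which swaps the 4-aminophenyl on the carbonyl carbon for a 3,4-dichlorophenyl and does not touch the methoxy-bearing ring.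

Compound 4 `COc1ccc(-c2cc(/C=C/C(=O)c3ccc(N)cc3)[nH]n2)cc1OC` differs from compound 2 by hydrogen in place of methoxy on an aromatic carbon. Within the data shown here, no measured step changes a methoxy group on that ring alone, so the closest guide is the pair of compound 1 and compound 2, which differ at that ring and give numbers fairly close together. A small step toward higher numbers, a number 7 percentage points higher from compound 2 to compound 4 (within the scatter), is therefore expected, likely within the scatter. Compound 4 is estimated at 50%, with a range from 36% to 64%.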

Compound 4, a percentage reported as activity, at one concentration (the size of the read-out at that concentration, not a potency): 71%
For compound 4 the middle estimate is 21 percentage points below the measured one; the measured number lies above the stated range.
By their numbers in this assay, from the lowest: compound 2; then compound 1; then compound 4; then compound 3.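

In this assay, the methoxy group ortho to a methoxy group and meta to a large group matters by itself: hydrogen in its place gives a number 28 percentage points higher from compound 2 to compound 4 (beyond the scatter), a change at this ring alone. Methoxy in place of hydrogen on the ring of compound 1 gives a number 13 percentage points higher from compound 1 to compound 4 (beyond the scatter), so among these three aminophenyl compounds the number does not follow the count of methoxy groups, and compound 4, with one methoxy fewer than compound 2 and one more than compound 1, lies above both. Nothing measured here accounts for this.

From the compounds shown here alone, whether a hydroxyl group, an ethoxy group or a fluorine atom at this place would fall nearer compound 2 or compound 4 stays open. So does whether hydrogen in place of this methoxy has a comparable effect when a 3,4-dichlorophenyl sits on the carbonyl carbon.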